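The source may hold more compounds than are shown below. What is called first, only, known or untested is meant among the compounds shown, and "the series" means these compounds.

Compound 1 `NC(=O)c1nc(C#Cc2ccc(F)cc2)n(COCCO)n1` is known in an ADME assay on Huh-5-2 cells (Homo sapiens) for cytotoxicity (on this read-out lower numbers stand for higher toxicity in this test and higher numbers for lower toxicity in this test), only as a limit. In this assay compound 1 gives > 160000 nM, which is a limit of the assay rather than a number. Compound 2 `NC(=O)c1nc(C#Cc2ccc(C(F)(F)F)cc2)n([C@@H]2O[C@H](CO)[C@@H](O)[C@H]2O)n1` gives 82500 nM in this assay. Compound 3 `COC(=O)c1nc(C#CC2(O)CCCC2)n([C@@H]2O[C@H](COC(C)=O)[C@@H](OC(C)=O)[C@H]2OC(C)=O)n1` gives > 105000 nM in this assay, again a limit. Compound 1 therefore stands at the limit of > 160000 nM in this assay, at which 1 of the 3 values shown sits. Going by the values given here, the other limit seen is the limit of > 105000 nM in this assay, at which 1 of the 3 values shown sits, and only one compound returns a numerical value.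

Compound 4 `NC(=O)c1nc(C#Cc2ccccc2)n(COCCO)n1` differs from compound 1 by hydrogen in place of fluoro on an aromatic carbon. Among the compounds with values here, no step between measured compounds involves a change of this kind, so no step size can be read from the data. Because compound 1 gives > 160000 nM only as a limit, the change is expected to produce no step beyond the scatter in this assay, in either direction. Compound 4 is accordingly estimated at 160000 nM, with a range from 80000 nM to 320000 nM. The expected step of a number no higher from compound 1 to compound 4 (the limit leaves the size open) is essentially none.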

Compound 4, half-maximal cytotoxic concentration: > 170000 nM
Compound 4 was reported as a limit (the forecaster's own chance of this, stated with the estimate: 70%); middle value at least 1.0-fold (0.02 log units) away from the limit.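

In this assay compound 4 gives > 170000 nM, which is a limit. Compound 1 is also known only as a limit, and no step can be read from compound 1 to compound 4. The compounds shown leave open whether hydrogen in place of fluoro on an aromatic carbon changes this read-out at all.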